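Benzoyl on the amide nitrogen of compound 2

This account rests on a few compounds, and the source may have more. Where it says the series, first, only, none or still open, it means among the compounds named here.

The study follows a pair of acylhydrazones and a third compound built from one of them. Compound 1 `O=C(N/N=C/c1c[nH]c2ccccc12)c1ccncc1` and compound 2 `COc1cccc(OC)c1/C=N/NC(=O)c1ccncc1` were both tested in an ADME assay on HEL cells (Homo sapiens) for cytotoxicity; on this read-out lower numbers stand for higher toxicity in this test and higher numbers for lower toxicity in this test. Compound 1 gives > 100 ug/mL in this assay, a value that is a limit of the assay and not a number. Compound 2 likewise gives > 100 ug/mL in this assay, again a limit rather than a number. For the measured compounds named here, compound 2 therefore stands at the limit of > 100 ug/mL in this assay, at which 2 of the 2 values shown sit, so the two measured compounds cannot be set in any order against each other, and no step between them can be counted.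

Compound 3 `COc1cccc(OC)c1/C=N/N(C(=O)c1ccccc1)C(=O)c1ccncc1` is the next compound, still to be measured in this assay. It differs from compound 2 by benzoyl in place of hydrogen on an amide-type nitrogen. With nothing beyond a shared limit to build on, the step from compound 2 is expected to be small, with no change beyond the usual scatter and at most a slight move towards higher toxicity, as a number no higher from compound 2 to compound 3 (the limit leaves the size open) states. Compound 3 is accordingly estimated at 100 ug/mL in this assay, within the range 25 ug/mL to 200 ug/mL.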

Compound 3, minimum cytotoxic concentration: > 100 ug/mL
Compound 3: no number, only a limit; the forecaster's own chance of this, stated with the estimate: 60%; the middle value sits exactly at the limit.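

In this assay compound 3 gives > 100 ug/mL, a limit of the assay and not a number. For the compounds shown here, compound 2 sits at the same limit, so no step from compound 2 to compound 3 can be read: the limit of > 100 ug/mL in this assay, at which 3 of the 3 values shown sit. The compounds shown leave open whether benzoyl on the amide-type nitrogen changes toxicity in these cells at all.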